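Two Methyl Groups Added to a Very Weak Inhibitor

The source may report more compounds than this note shows. Statements on the series, on what has been measured and on what is new or still open speak of the compounds shown alone.

Compound 1 `Cc1nnc(SCC(=O)[C@H](CC(=O)O)NC(=O)[C@@H](NC(=O)COc2cccc3ccccc23)C(C)C)s1` gives 190000 nM in a functional assay on Jurkat cells (Homo sapiens) for inhibition; a higher number here means a weaker inhibitor, a lower number a stronger inhibitor. Compound 2 `CC(C)[C@H](NC(=O)COc1cccc2ccccc12)C(=O)N[C@@H](CC(=O)O)C(=O)COc1ccncn1` reaches only the limit > 200000 nM in this assay.

For compound 2, then, no number is known, only that limit. Compound 3 `Cc1cc(OCC(=O)[C@H](CC(=O)O)NC(=O)[C@@H](NC(=O)COc2cccc3ccccc23)C(C)C)nc(C)n1` differs from compound 2 by 2,6-dimethylpyrimidin-4-yl in place of pyrimidin-4-yl on an oxygen on a saturated carbon. Within the data shown here, the only measured step, an at least 1.0-fold higher number from compound 1 to compound 2 (0.02 log units; that floor lies within the scatter), concerns a different change, lies within the scatter and ends at a limit (the limit of > 200000 nM in this assay, at which 1 of the 2 values shown sits). No shift beyond the scatter is expected here either. Compound 3 is therefore estimated at 200000 nM, with a range from 100000 nM to 400000 nM. The expected step is a number no higher from compound 2 to compound 3 (the limit leaves the size open).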

Compound 3, half-maximal inhibitory concentration: > 200000 nM
Compound 3 gave a limit, no number; the forecaster's own chance of this, stated with the estimate: 70%; the middle value sits exactly at the limit.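

Compound 3, which carries 2,6-dimethylpyrimidin-4-yl on the oxygen, also reaches only a limit in this assay: > 200000 nM. The step from compound 2 to compound 3 cannot be read because both values are limits: the limit of > 200000 nM in this assay, at which 2 of the 3 values shown sit. Adding the two methyl groups therefore brings no value under that limit, and putting (2,6-dimethylpyrimidin-4-yl)oxy in place of (5-methyl-1,3,4-thiadiazol-2-yl)sulfanyl gives an at least 1.0-fold higher number from compound 1 to compound 3 (0.02 log units; that floor lies within the scatter).

On these data alone, whether the methyl groups change inhibition at all stays open. So does whether an amine in their place would give a measurable number.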